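The compounds below may be only part of what the source reports. "The series", "measured", "known", "first", "only" and "open" are said of these compounds alone.

In a functional assay on C8166 cells (Homo sapiens) for cytotoxicity, read by MTT assay (a lower number here means that less compound is tolerated, a higher number that more compound is tolerated), three compounds built on a shared core have been measured. Compound 1 `Cc1cc(S(N)(=O)=O)ccc1NC(=O)COc1ccc(Cl)cc1NC(=O)c1ccccc1C` gives 67300 nM, compound 2 `Cc1ccc(C(=O)Nc2cc(Cl)ccc2OCC(=O)Nc2ccc(S(N)(=O)=O)cc2C)c(C)c1` gives 47600 nM, and compound 3 `Cc1cc(S(N)(=O)=O)ccc1NC(=O)COc1ccc(Cl)cc1NC(=O)c1ccc(Cl)cc1Cl` gives 61100 nM. These values lie within the scatter of one another, so compound 3 stands level with the other two.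

Compound 4 `Cc1cc(S(N)(=O)=O)ccc1NC(=O)COc1ccc(Cl)cc1NC(=O)c1cc(Cl)ccc1Cl` differs from compound 3 by a single change: 2,5-dichlorophenyl in place of 2,4-dichlorophenyl on a carbonyl carbon. For the measured compounds named here, no measured step exchanges these two groups, so the change has no direct precedent. The closest evidence comes from the two swaps of the group on this same carbonyl carbon, which gave a 1.1-fold lower number from compound 1 to compound 3 (0.04 log units; within the scatter) and a 1.3-fold higher number from compound 2 to compound 3 (0.11 log units; within the scatter). Adding a methyl on an aromatic carbon gave a 1.4-fold lower number from compound 1 to compound 2 (0.15 log units; within the scatter). All three steps are small.

The estimated step is a 1.1-fold lower number from compound 3 to compound 4 (0.02 log units; within the scatter), so no change beyond the scatter is expected in this assay. Compound 4 is estimated at 58000 nM, with an expected range of 35000 nM to 95000 nM.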

Compound 4, half-maximal cytotoxic concentration: 42100 nM
Compound 4: middle estimate off by 1.4-fold (0.14 log units), on the high side; the measured number falls inside the stated range.
By their numbers in this assay, from the lowest: compounds 4, 2, 3 and 1 (each within the scatter of the next).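

For the compounds shown here, exchanging 2,4-dichlorophenyl for 2,5-dichlorophenyl on the carbonyl carbon is the first change at this position that keeps the same atoms and only joins them differently, and in this assay it gives a 1.5-fold lower number from compound 3 to compound 4 (0.16 log units; within the scatter) with the step inside the scatter. The other two exchanges that bring in the 2,5-dichlorophenyl group give a 1.1-fold lower number from compound 2 to compound 4 (0.05 log units; within the scatter) and a 1.6-fold lower number from compound 1 to compound 4 (0.20 log units; within the scatter) and also stay inside the scatter, so all four groups seen on this carbonyl carbon stand level in this assay. Nothing in the data shown accounts for the values at this position.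

As far as these compounds go, the groups compared here are all phenyl rings carrying chlorine or methyl, so it remains open whether a carboxylic acid, an amine or a longer alkyl chain on this carbonyl carbon would move the number beyond the scatter. Every step shown also lies at this one place, leaving the rest of the shared core untested by these comparisons.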